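Methoxy for methylsulfanyl on the benzamide of compound 2

The source may report more compounds than this note shows. Statements on the series, on what has been measured and on what is new or still open speak of the compounds shown alone.

Compound 2 `CSc1cccc(C(=O)N2CCCC(C(=O)Nc3ccc(Cl)cc3)C2)c1` stands at the lower of the two numbers in an ADME assay on PC-3 cells (Homo sapiens) for cytotoxicity, read by WST assay, tested at 100 uM; on this read-out lower numbers stand for less inhibition and higher numbers for more inhibition at the one concentration tested (going by the name of the read-out); compound 2 gives 0%. For the measured compounds named here, compound 1 `O=C(Nc1ccc(Cl)cc1)C1CCCN(C(=O)c2cccc(-c3nccs3)c2)C1` is the nearest point, and in this assay compound 1 gives 32%; the one measured step, a number 32 percentage points lower from compound 1 to compound 2 (beyond the scatter), comes with the exchange of methylsulfanyl for 1,3-thiazol-2-yl on an aromatic carbon and is beyond the scatter.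

Compound 3 `COc1cccc(C(=O)N2CCCC(C(=O)Nc3ccc(Cl)cc3)C2)c1` is not yet measured. It differs from compound 2 in one place: methoxy in place of methylsulfanyl on an aromatic carbon.

Going by the values given here, no measured step swaps methoxy and methylsulfanyl, so the step from compound 1 to compound 2 is only an indirect guide, and its large size concerned a different group leaving. Compound 3 is therefore expected to stay near compound 2, with the step of a number 5 percentage points higher from compound 2 to compound 3 (within the scatter) expected to lie within the scatter. The estimate for compound 3 in this assay is 5%, with a range from 0% to 20%.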

Compound 3, a percentage reported as inhibition, at one concentration (the size of the read-out at that concentration, not a potency): 0%
The estimate for compound 3 lay 5 percentage points above the measured number; the range from low to high includes it.
By their numbers in this assay, from the lowest: compounds 2 and 3 (each within the scatter of the next); then compound 1.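

In this assay the exchange of methylsulfanyl for methoxy on an aromatic carbon, meta to a large group, gives no change at the digits printed from compound 2 to compound 3 (within the scatter) and so shows that this swap of two small groups does not separate the two compounds. Methoxy in place of 1,3-thiazol-2-yl gives a number 32 percentage points lower from compound 1 to compound 3 (beyond the scatter) in this assay and so repeats the large step seen with methylsulfanyl, which means the gap to compound 1 does not depend on methylsulfanyl alone. Nothing at hand explains why compound 1 stands apart from the other two.

On these data alone, whether an amine, a carboxylic acid or a longer chain at this place would read like compound 1 or like compound 3 remains open. Also open, as far as these compounds go, is whether an aromatic ring other than 1,3-thiazol-2-yl would keep the higher reading of compound 1.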